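A few compounds are considered here, and "the series" means these few. Any claim that something is new, unique, unknown or untested is made for them only; others in the source may bear on it.

Measured compounds:
compound 1, `N#CC1=C(/N=C/Nc2ccc([N+](=O)[O-])cc2)N(c2ccccc2)C(=O)N2CCCCC(N3CCCC3)C12`, giving 41.5%
compound 2, `COc1ccc(/C=N/C2=C(C#N)C3C(N4CCCC4)CCCCN3C(=O)N2c2ccccc2)cc1`, giving 71.6%

Going by the values given here, in a functional assay on the whole organism (strain albino) for inhibition, with Rattus norvegicus as the target, read by paw edema, with stated times of 1 h and 2 h, at a dose of 20 mmol/kg by the intraperitoneal route (a higher number here means more inhibition at the dose given (going by the name of the read-out), a lower number less inhibition), compound 2 gives 71.6%, the higher of the two numbers known; the nearest is compound 1 with 41.5%. Among the compounds with values here, the one measured step is a number 30.1 percentage points higher from compound 1 to compound 2 (beyond the scatter), in which 4-methoxyphenyl took the place of (4-nitrophenyl)amino on a carbon with a double bond to nitrogen. Compound 3, `N#CC1=C(/N=C/c2ccc([N+](=O)[O-])cc2)N(c2ccccc2)C(=O)N2CCCCC(N3CCCC3)C12`, differs from compound 2 by nitro in place of methoxy on an aromatic carbon. The measured step bears on this change only in part: it brought in the methoxy that now leaves, but it also removed the amino, which compound 3 does not carry. Because of a number 30.1 percentage points higher from compound 1 to compound 2 (beyond the scatter), the return of the nitro is expected to bring the number down toward compound 1, though by less than the whole of that step, since the amino stays absent. For compound 3 the expected step is a number 16.6 percentage points lower from compound 2 to compound 3 (beyond the scatter) in this assay, a decrease beyond the scatter but not a large one. The estimate for compound 3 is therefore 55%, with a range from 35% to 75%.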

Compound 3, a percentage reported as inhibition, in the whole organism at one dose (the size of the read-out at that dose, not a potency): 80.9%
For compound 3 the middle estimate is 25.9 percentage points below the measured one; the whole stated range lies below it.
By their numbers in this assay, from the lowest: compound 1; then compounds 2 and 3 (each within the scatter of the next).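

In this assay, nitro in place of methoxy on an aromatic carbon, para to a large group, gives a number 9.3 percentage points higher from compound 2 to compound 3 (within the scatter), so these two groups are not told apart at this place. The nitro therefore does not account for the low number of compound 1: with the nitro kept, 4-nitrophenyl in place of (4-nitrophenyl)amino on a carbon with a double bond to nitrogen gives a number 39.4 percentage points higher from compound 1 to compound 3 (beyond the scatter). Among these compounds, the large change thus goes with the loss of the amino, which the earlier step could not show, since it changed the amino and the methoxy together. Nothing available explains this difference.

What the compounds shown leave open is whether a carboxylic acid, a dimethylamino group or a chlorine on the same aromatic carbon would also fall within the scatter of compound 2 and compound 3. Also open, going by these compounds, is whether the amino would carry the same large step with methoxy in place of nitro, and whether any of this holds at doses other than the single one used.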